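This account rests on a few compounds, and the source may have more. Where it says the series, first, only, none or still open, it means among the compounds named here.

In a functional assay on B16 cells (Mus musculus) for antiproliferative activity, with a stated time of 72 h (on this read-out lower numbers stand for stronger inhibition and higher numbers for weaker inhibition), compound 3 `Cc1cccc(CNc2ncnc3c2ncn3[C@@H]2O[C@H](CO)[C@@H](O)[C@H]2O)c1` gives > 166000 nM as a limit and not a number. Compound 1 `OC[C@H]1O[C@@H](n2cnc3c(NCc4ccccc4F)ncnc32)[C@H](O)[C@@H]1O` gives > 166000 nM as a limit too. Compound 2 `OC[C@H]1O[C@@H](n2cnc3c(NCc4ccccc4Cl)ncnc32)[C@H](O)[C@@H]1O` gives > 166000 nM as a limit again. The record so far is the limit of > 166000 nM in this assay, at which 3 of the 3 values shown sit, and holds no exact number. Compound 4 `COc1cccc(CNc2ncnc3c2ncn3[C@@H]2O[C@H](CO)[C@@H](O)[C@H]2O)c1` has methoxy in place of methyl on an aromatic carbon compared with compound 3. The measured changes read a step that the two limits leave unreadable from compound 1 to compound 3 and a step that the two limits leave unreadable from compound 2 to compound 3 and a step that the two limits leave unreadable from compound 1 to compound 2 and so fix no size. No step beyond the scatter is therefore expected in this assay and no direction can be named. The expected step is a number no higher from compound 3 to compound 4 (the limit leaves the size open) and nothing larger. For compound 4 the estimate is 166000 nM with a range from 50000 nM to 300000 nM and most likely only a limit will be reported.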

Compound 4, half-maximal inhibitory concentration: > 166000 nM
Compound 4: only a limit was reported; the forecaster's own chance of this, stated with the estimate: 80%; the middle value sits exactly at the limit.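

Compound 4, like compound 1, compound 2 and compound 3, gives only a limit in this assay, so no step among these compounds can be read. The compounds shown leave open whether any of these changes shifts inhibition at all.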